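Swapping the carbonyl-bound ring in a sulfonamide series

The source may report more compounds than this note shows. Statements on the series, on what has been measured and on what is new or still open speak of the compounds shown alone.

Compound 1 `O=C(NCc1ccc(CNS(=O)(=O)c2ccc3c(c2)CCO3)cc1)c1cccc2c1COC2`: 40%
Compound 2 `O=C(NCc1ccc(CNS(=O)(=O)c2ccc(F)cc2F)cc1)c1cncnc1`: 74%
Compound 3 `Cc1nnsc1C(=O)NCc1ccc(CNS(=O)(=O)c2ccc(F)c(F)c2)cc1`: 40%

Of the compounds shown here, three sharing the same benzylamide-sulfonamide core have been tested in an assay on cells for inhibition of C-X-C chemokine receptor type 4 (Homo sapiens), with a stated time of 22 h, tested at 100 nM; on this read-out lower numbers stand for less inhibition and higher numbers for more inhibition at the one concentration tested (going by the name of the read-out). Compound 1 gives 40%, level with compound 3 at the digits shown and within the scatter of it; together the two stand lowest of the three. Compound 2 lies furthest from compound 1, its reading being higher by a margin beyond the scatter.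

Compound 4 `O=C(NCc1ccc(CNS(=O)(=O)c2ccc3c(c2)CCO3)cc1)c1cccnc1` differs from compound 1 only at the carbonyl carbon: a group of 6 heavy atoms (5 carbon, 1 nitrogen; one six-membered aromatic ring with 1 hetero atom) in place of a group of 9 heavy atoms (8 carbon, 1 oxygen; one five-membered non-aromatic ring with 1 hetero atom, one six-membered aromatic ring of carbon only), on a carbonyl carbon. Among the compounds with values here, no step between two measured compounds isolates this change, since compound 2 and compound 3 also differ from compound 1 at the sulfonyl-bound ring. Still, compound 2, which carries a small six-membered aromatic ring with hetero atoms on the carbonyl carbon, gives the higher reading, and on that basis a moderate rise in this assay is expected for compound 4, roughly a step of a number 12 percentage points higher from compound 1 to compound 4 (beyond the scatter). Compound 4 is therefore estimated at 52%, within a range from 30% to 74%.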

Compound 4, a percentage reported as inhibition, at one concentration (the size of the read-out at that concentration, not a potency): 60%
Beside the measured number, compound 4's estimate is 8 percentage points below it; low and high end bracket the measured number.
By their numbers in this assay, from the lowest: compounds 1 and 3 (each within the scatter of the next); then compound 4; then compound 2.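

Within the data shown here, with the rest of the molecule unchanged, placing pyridin-3-yl on the carbonyl carbon in this assay gives a number 20 percentage points higher from compound 1 to compound 4 (beyond the scatter) and so provides the first reading for this position on its own. The earlier compounds shown here also differed at the sulfonyl-bound ring, so they could not show that the group on the carbonyl carbon alone moves the reading beyond the scatter. Nothing measured here accounts for the step.

The change removes the five-membered non-aromatic ring, shrinks the group and brings in a ring nitrogen all at once, so the compounds shown do not tell these apart. A phenyl group on the carbonyl carbon, with the rest of compound 4 kept, would separate the ring nitrogen from the other two changes.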